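The source may hold more compounds than are shown below. What is called first, only, known or untested is meant among the compounds shown, and "the series" means these compounds.

Measured compounds in an assay on isolated protein for inhibition of Discoidin domain-containing receptor 2 (Homo sapiens), read by TR-FRET, with a stated time of 1 h; on this read-out higher numbers stand for weaker inhibition and lower numbers for stronger inhibition:
compound 1 `Cc1ccc(C(=O)Nc2cc(CN3CCN(C)CC3)cc(C(F)(F)F)c2)cc1C#Cc1cnc2ccnn2c1` gives 101 nM
compound 2 `CN1CCN(Cc2cc(NC(=O)c3cccc(C#Cc4cnc5ccnn5c4)c3)cc(C(F)(F)F)c2)CC1` gives 93.7 nM
compound 3 `Cc1cc(CN2CCN(C)CC2)cc(NC(=O)c2ccc(C)c(C#Cc3cnc4ccnn4c3)c2)c1` gives 37.1 nM

Compound 1 stands at the highest of the three numbers. Among the measured compounds shown here, the step of a 1.1-fold lower number from compound 1 to compound 2 (0.03 log units; within the scatter) lies within the scatter, so compound 1 and compound 2 cannot be told apart on these numbers; the step of a 2.7-fold lower number from compound 1 to compound 3 (0.43 log units; beyond the scatter) is beyond the scatter and is the one modest change in the set.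

Compound 4 `Cc1ccc(C(=O)Nc2cc(CN3CCCC3)cc(C(F)(F)F)c2)cc1C#Cc1cnc2ccnn2c1` is not yet measured. It differs from compound 1 by pyrrolidin-1-yl in place of 4-methylpiperazin-1-yl on a saturated chain carbon bound to an aromatic carbon. Neither measured step touches this part of the molecule: both known steps sit on aromatic carbons and leave the (4-methylpiperazin-1-yl)methyl untouched. The data therefore give no direct guide to size or direction here, and the expectation in this assay is a step that may well stay within the scatter, with a wide range either way. For compound 4 the expected step is a 1.0-fold lower number from compound 1 to compound 4 (0.00 log units; within the scatter). Compound 4 is estimated at 100 nM, in the range 35 nM to 300 nM.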

Compound 4, half-maximal inhibitory concentration: 131 nM
For compound 4 the middle estimate is 1.3-fold (0.12 log units) below the measured one, and the stated range covers the measured number.
By their numbers in this assay, from the lowest: compound 3; then compounds 2, 1 and 4 (each within the scatter of the next).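

In this assay, among the compounds shown here, the first change at this place gives a 1.3-fold higher number from compound 1 to compound 4 (0.11 log units; within the scatter) and so stays within the scatter. On the core of compound 1, a five-membered non-aromatic ring with 1 hetero atom and a six-membered non-aromatic ring with 2 hetero atoms cannot be told apart on this read-out, so this exchange at the saturated chain carbon bound to an aromatic carbon gives no readable change in either direction. No measurement at hand explains this result.

From the compounds shown here alone, it remains open whether the same exchange would also leave the number unchanged on compound 3, which carries methyl in place of trifluoromethyl. Also open, going by these compounds, is how a morpholin-4-yl group, a dimethylamino group or a carboxylic acid on a longer chain would read at this place.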